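Aromatic substituent changes on the shared core

The source may report more compounds than this note shows. Statements on the series, on what has been measured and on what is new or still open speak of the compounds shown alone.

Of the compounds shown here, two have been measured in an assay on microsomes from liver for inhibition of 3-hydroxy-3-methylglutaryl-coenzyme A reductase (Sus scrofa), read by colorimetric assay; on this read-out higher numbers stand for weaker inhibition and lower numbers for stronger inhibition. Compound 1 `CC(C)=CCC/C(C)=C/CCC1=C[C@H](c2ccccc2[N+](=O)[O-])OC1=O` gives 18900 nM. Compound 2 `COCOc1ccccc1[C@H]1C=C(CC/C=C(\C)CCC=C(C)C)C(=O)O1`, which carries methoxymethoxy in place of nitro on the aromatic carbon, gives 8900 nM in this assay; the step of a 2.1-fold lower number from compound 1 to compound 2 (0.33 log units; beyond the scatter) is modest but beyond the scatter. Among the compounds with values here, on the numbers so far compound 2 stands as the lower of the two, with compound 1 as its only neighbour at the higher number.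

Compound 3 `CC(C)=CCC/C(C)=C/CCC1=C[C@H](c2ccccc2O)OC1=O` differs from compound 2 by hydrogen in place of methoxymethyl on an oxygen on an aromatic ring. Within the data shown here, no measured step involves this oxygen; the single step known, from compound 1 to compound 2, concerns exchange of the whole group on the aromatic carbon and was modest, so it gives only weak guidance here. With nothing pointing to a large change, a step in this assay no larger than the scatter, if anything toward a slightly lower number, is expected for compound 3, corresponding to a 1.2-fold lower number from compound 2 to compound 3 (0.07 log units; within the scatter). The estimate for compound 3 in this assay is therefore 7500 nM, within a range from 2500 nM to 25000 nM.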

Compound 3, half-maximal inhibitory concentration: 6760 nM
Compound 3: the middle estimate sits 1.1-fold (0.05 log units) above what was measured; low and high end bracket the measured number.
By their numbers in this assay, from the lowest: compounds 3 and 2 (each within the scatter of the next); then compound 1.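

Working notes on the oxygen on the aromatic ring: in this assay hydrogen in place of methoxymethyl gives a 1.3-fold lower number from compound 2 to compound 3 (0.12 log units; within the scatter) and so leaves compound 2 and compound 3 unseparated, which means that the methoxymethyl group can go without a readable difference on this read-out. Hydroxy in place of nitro on the aromatic carbon gives a 2.8-fold lower number from compound 1 to compound 3 (0.45 log units; beyond the scatter) as its step, so the separation from compound 1 seen earlier with methoxymethoxy is now also seen with hydroxy, and in this set of three compounds only the nitro compound stands apart. No measurement at hand bears on the reason for either step.

Whether the oxygen tolerates anything between hydrogen and methoxymethyl, or something larger such as a benzyl group or a longer chain, remains open, since only these two substituents on it are shown. Also open, on these data alone, is whether the aromatic carbon can carry a group without this oxygen, such as an amine or a carboxylic acid, and whether such a group would read with compound 1 or with the other two compounds.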